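Methoxy on the phenyl ring of the indole-oxadiazole series

The compounds below may be only part of what the source reports. "The series", "measured", "known", "first", "only" and "open" are said of these compounds alone.

Measured so far:
compound 1, `COc1ccc2[nH]c(-c3nc(-c4ccccc4)no3)cc2c1`: 32600 nM
compound 2, `O=[N+]([O-])c1ccc2[nH]c(-c3nc(-c4ccccc4)no3)cc2c1`: > 50000 nM

Going by the values given here, in a functional assay on MIA PaCa-2 cells (Homo sapiens) for antiproliferative activity, read by WST assay, with a stated time of 72 h (on this read-out higher numbers stand for weaker inhibition and lower numbers for stronger inhibition), compound 1 gives 32600 nM, the only number obtained. For compound 2 the assay returns only the limit > 50000 nM (the limit of > 50000 nM in this assay, at which 1 of the 2 values shown sits). The step of an at least 1.5-fold higher number from compound 1 to compound 2 (0.18 log units; that floor lies within the scatter) concerns the other ring and does not bear on the change in hand.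

Compound 3, `COc1ccc(-c2noc(-c3cc4cc(OC)ccc4[nH]3)n2)cc1`, differs from compound 1 by methoxy in place of hydrogen on an aromatic carbon, which is to say a phenyl becoming a 4-methoxyphenyl. Among the compounds with values here, no measured step speaks to this change, so no step beyond the scatter is expected: the estimated step is a 1.1-fold lower number from compound 1 to compound 3 (0.04 log units; within the scatter). Compound 3 is therefore expected near 30000 nM, between 12000 nM and 80000 nM.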

Compound 3, half-maximal inhibitory concentration: 5600 nM
Beside the measured number, compound 3's estimate is 5.4-fold (0.73 log units) above it; measured number outside the range, below it.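

Going from phenyl to 4-methoxyphenyl in this assay brings a 5.8-fold lower number from compound 1 to compound 3 (0.77 log units; beyond the scatter) and shows that this place, para to a large group, responds to substitution. The earlier step concerned the other ring, and its floor lay within the scatter, so this is the first change in the series shown to move the number beyond it. No measured property shown here accounts for the step.

From the compounds shown here alone, whether the change depends on methoxy itself stays open. A hydroxyl, an amine or an ethoxy group at this place would test that.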